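Acyl variation on a shared amide core: outlook for compound 3

The compounds below may be only part of what the source reports. "The series", "measured", "known", "first", "only" and "open" are said of these compounds alone.

Measured compounds:
compound 1 `CCCCC(=O)N(Cc1ccc(OC)c(O)c1)c1cc(OC)c(OC)c(OC)c1` — 170 nM
compound 2 `COc1ccc(CN(C(=O)C(C)Br)c2cc(OC)c(OC)c(OC)c2)cc1O` — 140 nM

In a functional assay on HCT-116 cells (Homo sapiens) for inhibition, read by MTT assay, with a stated time of 48 h (on this read-out lower numbers stand for stronger inhibition and higher numbers for weaker inhibition), compound 1 gives 170 nM and compound 2 gives 140 nM. The only step measured so far, a 1.2-fold lower number from compound 1 to compound 2 (0.08 log units; within the scatter), exchanges the group on the carbonyl carbon and leaves the read-out within the scatter; compound 2 and compound 1 are thus not distinguished on the numbers shown, and compound 2 stands within the scatter of the one other compound.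

Compound 3 `C=C(C)C(=O)N(Cc1ccc(OC)c(O)c1)c1cc(OC)c(OC)c(OC)c1` continues the same line of variation. Its difference from compound 2: 1-methylethenyl in place of 1-bromoethyl on a carbonyl carbon

For the measured compounds named here, the single step that bears on this change is the one from compound 1 to compound 2, which also replaced the group on the carbonyl carbon and moved the number only within the scatter. Going by the values given here, no measured step shows that the carbonyl substituent shifts the read-out beyond the scatter, so no step beyond the scatter is expected here either, in either direction.

Compound 3 is therefore expected to give about 150 nM, with a range of 70 nM to 330 nM. The expected step is a 1.1-fold higher number from compound 2 to compound 3 (0.03 log units; within the scatter).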

Compound 3, half-maximal inhibitory concentration: 200 nM
Estimate against measurement, compound 3: 1.3-fold (0.12 log units) below; the measured number falls inside the stated range.
By their numbers in this assay, from the lowest: compounds 2, 1 and 3 (each within the scatter of the next).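

Working notes on the carbonyl position: in this assay, a 1.4-fold higher number from compound 2 to compound 3 (0.15 log units; within the scatter) and a 1.2-fold higher number from compound 1 to compound 3 (0.07 log units; within the scatter) are the steps that now join the first one, so butyl, 1-bromoethyl and 1-methylethenyl all stand within the scatter of one another on this carbonyl carbon. For the compounds shown here, the earlier pair compared only two saturated groups, whereas the new group brings a double bond outside aromatic rings and carries no bromine, and neither difference separates compound 3 from compound 2 or compound 1 on these numbers. No measurement offered here gives a reason for this lack of separation among the three groups.

The compounds shown leave open whether any group on this carbonyl carbon moves the read-out beyond the scatter, for instance a chain ending in an amine or a carboxylic acid, or a much longer alkyl chain. As far as these compounds go, the rest of the shared core stays the same in all three compounds, so what its parts contribute to the read-out also remains open.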